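Aryl substituent change in the piperazine-pyridyl branch

The source may report more compounds than this note shows. Statements on the series, on what has been measured and on what is new or still open speak of the compounds shown alone.

Compound 1 `COC(=O)C1(c2ccc(C)cc2)CC1CN1CCC(Cc2ccccc2)CC1` gives 0.97 nM in an assay for displacement of a labelled ligand from Sigma non-opioid intracellular receptor 1 (Cavia porcellus); on this read-out lower numbers stand for stronger inhibition and higher numbers for weaker inhibition. Going by the values given here, compound 3 `COC(=O)C1(c2ccccc2)CC1CN1CCC(Cc2ccccc2)CC1` gives 2.2 nM, and the only single-point step in the set is a 2.3-fold higher number from compound 1 to compound 3 (0.36 log units; beyond the scatter). Compound 2 `COC(=O)C1(c2ccc(C)cc2)CC1CN1CCN(c2ccccn2)CC1` gives 497 nM and stands highest of the three numbers, beyond the scatter against compound 3 and against compound 1. Compound 4 `COC(=O)C1(c2ccc(N)cc2)CC1CN1CCN(c2ccccn2)CC1` is not yet measured; it differs from compound 2 by amino in place of methyl on an aromatic carbon. Among the compounds with values here, no measured pair exchanges methyl for amino, and no measured pair changes anything on the core of compound 2. Within the data shown here, the one step that bears on the same aromatic carbon is the methyl-to-hydrogen step above, which was modest and ran toward a higher number. The expected step of a 1.4-fold higher number from compound 2 to compound 4 (0.15 log units; within the scatter) is therefore modest, toward a higher number, and may not clear the scatter. Compound 4 is expected at 700 nM in this assay, with a range from 200 nM to 2500 nM.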

Compound 4, inhibition constant: > 10000 nM
Compound 4: a limit, no number; the forecaster's own chance of this, stated with the estimate: 10%; middle value at least 14-fold (1.15 log units) away from the limit.
By their numbers in this assay, from the lowest: compound 1; then compound 3; then compound 2. At a limit, above all of these: compound 4.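

Amino in place of methyl on the aromatic carbon para to a large group is far from a silent exchange in this assay: the change gives an at least 20-fold higher number from compound 2 to compound 4 (1.30 log units; beyond the scatter). Going by these compounds alone, the only earlier step at this carbon, a 2.3-fold higher number from compound 1 to compound 3 (0.36 log units; beyond the scatter), was modest and sits on a different core, so these two steps show that this carbon can carry a large change in the read-out, not only a small one. The reading for compound 4 is a limit and not a number: the limit of > 10000 nM in this assay, at which 1 of the 4 values shown sits.

Still open, as far as these compounds go, is whether amino on the core of compound 1 would give a step of similar size, or whether the large step belongs to the core of compound 2. Also open, from the compounds shown here alone, is how hydroxyl, methoxy or a plain hydrogen at this carbon would read on the core of compound 2.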